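The source may report more compounds than this note shows. Statements on the series, on what has been measured and on what is new or still open speak of the compounds shown alone.

Measured compounds:

Compound 1, `O=C(O)CC1COc2cc(OCc3ncc(-c4ccccc4)o3)ccc21`, in a functional assay on CHO cells for agonist activity at Free fatty acid receptor 1 (Homo sapiens), read by FLIPR and calcium flux, tested at 100 nM (a lower number here means a weaker effect, a higher number a stronger effect of the compound at the concentration tested), gives 2.34%.
Compound 2, `O=C(O)CC1COc2cc(OCc3ncc(-c4ccccc4)s3)ccc21`, in this assay gives 5.26%.
Compound 3, `Cc1nc(-c2ccc(Cl)s2)sc1COc1ccc2c(c1)OCC2CC(=O)O`, in this assay gives 8.34%.

The three compounds share one core carrying the carboxylic acid and differ only in the group at the far end of the molecule. Compound 3 gives the largest of the three numbers, yet its gaps to compound 2 and to compound 1 both fall within the usual scatter of this kind of measurement, so the three read as alike and no ordering among them can be claimed. For the measured compounds named here, none of the pairs differs in a single place, so no measured step is available to lean on.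

Compound 4, `COc1cc(OC)cc(-c2nc(C)c(COc3ccc4c(c3)OCC4CC(=O)O)s2)c1`, is the next compound. Compared with compound 3 the change is this:

3,5-dimethoxyphenyl in place of 5-chlorothiophen-2-yl on an aromatic carbon

With nothing but three low and mutually indistinguishable numbers to go on, the step from compound 3 to compound 4 is expected to stay within the scatter, a number 1.7 percentage points higher from compound 3 to compound 4 (within the scatter), neither clearly up nor clearly down. Compound 4 is therefore estimated at 10%, with a plausible range from 2% to 30%.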

Compound 4, a percentage reported as activity, at one concentration (the size of the read-out at that concentration, not a potency): 17.5%
Compound 4: middle estimate off by 7.5 percentage points, on the low side; the measured number falls inside the stated range.
By their numbers in this assay, from the lowest: compounds 1, 2, 3 and 4 (each within the scatter of the next, the first and the last beyond it).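

This position, an aromatic carbon of the five-membered aromatic ring with 1 nitrogen and 1 sulfur, now has its first single-place comparison: exchanging 5-chlorothiophen-2-yl for 3,5-dimethoxyphenyl gives a number 9.2 percentage points higher from compound 3 to compound 4 (within the scatter) in this assay at the one concentration tested. The exchange replaces a five-membered aromatic ring with 1 hetero atom and 6 heavy atoms by a six-membered aromatic ring of carbon only and 10 heavy atoms, so a marked change in the entering group leaves the read-out indistinguishable within the scatter. No measured information on the cause of this outcome is available here.

The step changes the ring and its substituents together, so the compounds shown cannot separate the contribution of the chlorine from that of the two methoxy groups or of the ring itself. Also open is how a pyridine ring, or a phenyl ring bearing an amine or a single methoxy group, would read at this carbon, and whether any of these compounds would give a different picture at another concentration.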